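Leaving the Benzyloxy Extreme: Expected Clearance of Compound 4

A few compounds are considered here, and "the series" means these few. Any claim that something is new, unique, unknown or untested is made for them only; others in the source may bear on it.

- Compound 1 `CNC(=O)[C@@H]1CCCN1S(=O)(=O)c1ccc(Cl)c(COc2cccc3c(-n4ccnc4)cc(C)nc23)c1Cl`: 33.3 mL/min/kg
- Compound 2 `CNC(=O)[C@@H]1CCCN1S(=O)(=O)c1ccc(Cl)c(COc2cccc3c(-c4cncn4C)cc(C)nc23)c1Cl`: 33.3 mL/min/kg
- Compound 3 `CNC(=O)[C@@H]1CCCN1S(=O)(=O)c1ccc(Cl)c(COc2cccc3c(OCc4ccccc4)cc(C)nc23)c1Cl`: 467 mL/min/kg

In an ADME assay on microsomes (Homo sapiens) for metabolic stability (a higher number here means faster removal of the compound, a lower number slower removal), compound 3 stands highest of the three at 467 mL/min/kg. Compound 4 `CNC(=O)[C@@H]1CCCN1S(=O)(=O)c1ccc(Cl)c(COc2cccc3c(-c4cccnc4)cc(C)nc23)c1Cl` carries pyridin-3-yl in place of the benzyloxy of compound 3, on an aromatic carbon opposite the ring nitrogen (pyridin-3-yl in place of benzyloxy on an aromatic carbon). Among the measured compounds shown here, three measured steps bear on this. Benzyloxy in place of 1H-imidazol-1-yl gave a 14-fold higher number from compound 1 to compound 3 (1.15 log units; beyond the scatter), and benzyloxy in place of 1-methyl-1H-imidazol-5-yl gave a 14-fold higher number from compound 2 to compound 3 (1.15 log units; beyond the scatter), both large. Exchanging the two imidazole groups gave no change at the digits printed from compound 1 to compound 2 (within the scatter). Pyridin-3-yl itself has not been measured, so the comparison with these two aromatic ring groups is only an analogy. A large fall is nonetheless expected on leaving benzyloxy, perhaps not quite reaching the level of compound 2 at 33.3 mL/min/kg. The estimated step is a 10-fold lower number from compound 3 to compound 4 (1.02 log units; beyond the scatter). Compound 4 is expected at 45 mL/min/kg, with an estimated range from 20 mL/min/kg to 120 mL/min/kg.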

Compound 4, clearance: 233 mL/min/kg
Estimate against measurement, compound 4: 5.2-fold (0.71 log units) below, and the stated range ends below it.
By their numbers in this assay, from the lowest: compounds 1 and 2 (each within the scatter of the next); then compounds 4 and 3 (each within the scatter of the next).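

In this assay, pyridin-3-yl in place of benzyloxy gave a 2.0-fold lower number from compound 3 to compound 4 (0.30 log units; within the scatter) and so did not bring compound 4 to the level of the imidazole compounds. Pyridin-3-yl in place of the two imidazole groups gave a 7.0-fold higher number from compound 2 to compound 4 (0.84 log units; beyond the scatter) and a 7.0-fold higher number from compound 1 to compound 4 (0.84 log units; beyond the scatter) on the same aromatic carbon opposite the ring nitrogen, so among these compounds the divide runs between the two imidazole groups and the other two groups, not between aromatic ring groups and benzyloxy. Nothing measured here accounts for that divide.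

The compounds shown leave open whether the lower numbers belong to imidazole alone or would also appear with a pyrazol-4-yl or thiazol-5-yl group at this place. A plain phenyl group or a saturated amine such as morpholin-4-yl also remains to be placed against these four compounds.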